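The source may report more compounds than this note shows. Statements on the series, on what has been measured and on what is new or still open speak of the compounds shown alone.

Compound 1 `C=C1C(=O)OC[C@H]1CCOC(=O)Nc1ccc(I)cc1` gives 490 nM
Compound 2 `C=C1C(=O)OC[C@H]1CCOC(=O)Nc1ccc(C(=O)OCCCC)cc1` gives 430 nM

Within the data shown here, in a functional assay on RAW264.7 cells (Mus musculus) for inhibition, with a stated time of 30 min (on this read-out lower numbers stand for stronger inhibition and higher numbers for weaker inhibition), compound 2 stands alongside compound 1, the only other measured compound: the step of a 1.1-fold lower number from compound 1 to compound 2 (0.06 log units; within the scatter) keeps the two within the scatter of each other. Compound 3 `C=C1C(=O)OC[C@H]1CCOC(=O)Nc1ccccc1` differs from compound 2 by hydrogen in place of butoxycarbonyl on an aromatic carbon. Among the measured compounds shown here, the one measured step that bears on this position, a 1.1-fold lower number from compound 1 to compound 2 (0.06 log units; within the scatter), shows the exchange of one group for another at that aromatic carbon leaving the number essentially unchanged. A change of similar small size is therefore expected for compound 3 in this assay, with no direction beyond the scatter. Compound 3 is estimated at 600 nM, in the range 250 nM to 1500 nM. That estimate means a step of a 1.4-fold higher number from compound 2 to compound 3 (0.14 log units; within the scatter).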

Compound 3, half-maximal inhibitory concentration: 390 nM
Compound 3: the middle estimate sits 1.5-fold (0.19 log units) above what was measured, and the stated range covers the measured number.
By their numbers in this assay, from the lowest: compounds 3, 2 and 1 (each within the scatter of the next).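

Hydrogen at this aromatic carbon, with no group there at all, now gives a reference point in this assay and shows a 1.1-fold lower number from compound 2 to compound 3 (0.04 log units; within the scatter) and a 1.3-fold lower number from compound 1 to compound 3 (0.10 log units; within the scatter) for the loss of butoxycarbonyl and of iodo. Neither group is therefore needed at this carbon for the number seen here, and the three compounds stand together within the scatter. Nothing at hand gives a reason for this.

The compounds shown leave open whether an amine or a carboxylic acid at this aromatic carbon would move the number beyond the scatter.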